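Moving a nitro for a nitrile on a thiohydantoin series

The compounds below may be only part of what the source reports. "The series", "measured", "known", "first", "only" and "open" are said of these compounds alone.

Compound 1 `CC1(C)C(=O)N(c2ccc(C#N)cc2C(F)(F)F)C(=S)N1c1ccc(S(F)(F)(F)(F)F)cc1` and compound 2 `CC1(C)C(=O)N(c2ccc(C#N)cc2C(F)(F)F)C(=S)N1c1cccc(S(F)(F)(F)(F)F)c1` share the same atoms joined differently; the difference between the two cores is not broken down here. In a functional assay on LNCaP cells (Homo sapiens) for antiproliferative activity, read by propidium iodide staining, with a stated time of 96 h (a higher number here means a weaker inhibitor, a lower number a stronger inhibitor), compound 1 gives 3000 nM, and compound 2 gives 4100 nM, two numbers within the usual scatter of each other. Compound 3 `CC1(C)C(=O)N(c2ccc([N+](=O)[O-])cc2C(F)(F)F)C(=S)N1c1ccc(S(F)(F)(F)(F)F)cc1` carries a nitro in place of cyano on an aromatic carbon, and compound 3 gives 100000 nM in this assay, a step of a 33-fold higher number from compound 1 to compound 3 (1.52 log units; beyond the scatter). Compound 4 `CC1(C)C(=O)N(c2ccc([N+](=O)[O-])cc2C(F)(F)F)C(=S)N1c1cccc(S(F)(F)(F)(F)F)c1` is the matching change on the core of compound 2: nitro in place of cyano on an aromatic carbon, at a place described in the same words. Because the same change gave a 33-fold higher number from compound 1 to compound 3 (1.52 log units; beyond the scatter), a comparable step of a 24-fold higher number from compound 2 to compound 4 (1.39 log units; beyond the scatter) is expected for compound 4, with the estimate for compound 4 in this assay at 100000 nM, between 30000 nM and 300000 nM.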

Compound 4, half-maximal inhibitory concentration: 5300 nM
The estimate for compound 4 lay 19-fold (1.28 log units) above the measured number; measured number below the stated range.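

Replacing cyano with nitro on the core of compound 2 gives a 1.3-fold higher number from compound 2 to compound 4 (0.11 log units; within the scatter) in this assay. This change therefore does not bring a fixed step from one core to the other in this series: the same change on two cores in this assay, a 33-fold higher number (1.52 log units; beyond the scatter) from compound 1 to compound 3 and a 1.3-fold higher number (0.11 log units; within the scatter) from compound 2 to compound 4, 26-fold (1.41 log units) apart, beyond the scatter of two such steps

Going by these compounds alone, with only one pair on each core, this shows that the outcome depends on the core but does not show why, or what the change would do on any further core.

The compounds shown leave open whether other groups in that place, such as an amine or a carboxylic acid, would follow the core of compound 1 or the core of compound 2.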